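Swapping a triazole for a tert-butoxy group

The source may hold more compounds than are shown below. What is called first, only, known or untested is meant among the compounds shown, and "the series" means these compounds.

Measured compounds:
- compound 1, `C(=C1\CCCN=C1c1cccnc1)\c1ccc(-n2ccnn2)cc1`: 520 nM
- compound 2, `COc1ccc(/C=C2\CCCN=C2c2cccnc2)c(OC(C)=O)c1`: 770 nM
- compound 3, `CCN(CC)c1ccc(/C=C2\CCCN=C2c2cccnc2)c(O)c1`: 130 nM

All three were tested in an assay on membranes from brain for displacement of a labelled ligand from Neuronal acetylcholine receptor; alpha4/beta2 (Rattus norvegicus), with a stated time of 3 h; on this read-out higher numbers stand for weaker inhibition and lower numbers for stronger inhibition. Compound 1 gives 520 nM, the second highest of the three numbers. Its nearest neighbour is compound 2, whose value of 770 nM lies within the usual scatter of such measurements, so the two cannot be told apart. Compound 3, at 130 nM, stands furthest away, a gap that does lie beyond the scatter.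

The unmeasured compound 4, `CC(C)(C)Oc1ccc(/C=C2\CCCN=C2c2cccnc2)cc1`, differs from compound 1 in a single place: tert-butoxy in place of 1H-1,2,3-triazol-1-yl on an aromatic carbon. The change sits on an aromatic carbon of a six-membered aromatic ring of carbon only, para to a large group.

Among the measured compounds shown here, no measured pair shows what such a swap does, so the expected step from compound 1 to compound 4 is estimated to stay within the scatter, with no direction claimed. Compound 4 is estimated at 450 nM, within 120 nM to 1700 nM. That estimate corresponds to a step of a 1.2-fold lower number from compound 1 to compound 4 (0.06 log units; within the scatter).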

Compound 4, inhibition constant: 2170 nM
Beside the measured number, compound 4's estimate is 4.8-fold (0.68 log units) below it, outside the stated range (above it).
By their numbers in this assay, from the lowest: compound 3; then compounds 1 and 2 (each within the scatter of the next); then compound 4.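

Among the compounds shown here, at this place, on an aromatic carbon para to a large group, the swap of 1H-1,2,3-triazol-1-yl for tert-butoxy gives a 4.2-fold higher number from compound 1 to compound 4 (0.62 log units; beyond the scatter) in this assay, the first single-place step. The position is therefore not indifferent to what sits on it: two groups with the same count of heavy atoms are clearly told apart, and the triazole-bearing compound 1 shows the stronger inhibition. Nothing on hand says what lies behind this difference.

Still open, from the compounds shown here alone, is which feature matters, the triazole ring with its nitrogens or the branched tert-butoxy group, as a single swap changes both at once. A nitrile or a carboxylic acid on the same carbon would show how far the number moves with groups of quite another kind.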